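Methoxy to trifluoromethoxy: expected clearance of compound 4

This account rests on a few compounds, and the source may have more. Where it says the series, first, only, none or still open, it means among the compounds named here.

Measured in an ADME assay on the whole organism (strain Sprague-Dawley) for pharmacokinetics, with Rattus norvegicus as the target, using cassette dosing (a lower number here means slower removal, a higher number faster removal of the compound), so far:
compound 1 `O=c1ccc(-c2cc(C[C@]3(O)CC[C@H](Cc4ccc(Cl)cc4)CC3)no2)c[nH]1` gives 6.6 mL/min/kg in this series
compound 2 `O[C@]1(Cc2cc(-c3cn[nH]c3)on2)CC[C@H](Cc2ccccc2)CC1` gives 56.5 mL/min/kg in this series
compound 3 `COc1ccc(C[C@H]2CC[C@](O)(Cc3cc(-c4cn[nH]c4)on3)CC2)cc1` gives 61.8 mL/min/kg in this series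

Compound 2 and compound 3 lie within the scatter of each other at the top of this small set, and compound 1 stands well below both, beyond the scatter. The next compound is compound 4 `O[C@]1(Cc2cc(-c3cn[nH]c3)on2)CC[C@H](Cc2ccc(OC(F)(F)F)cc2)CC1` which differs from compound 3 in one place trifluoromethyl in place of methyl on an oxygen on an aromatic ring with trifluoromethyl in place of methyl on an oxygen on an aromatic ring. Among the compounds with values here, the one measured step that bears on this is a 1.1-fold higher number from compound 2 to compound 3 (0.04 log units; within the scatter) for methoxy in place of hydrogen on an aromatic carbon, and that step stays within the scatter. Compound 1 differs from compound 3 in more than one place and gives no reading on this change alone. Within the data shown here, no measured step covers trifluoromethoxy itself, so no step beyond the scatter is expected in this assay and the range is kept wide. The estimate means an expected 1.4-fold lower number from compound 3 to compound 4 (0.14 log units; within the scatter) and no more than that. Compound 4 is expected at 45 mL/min/kg within an estimated range of 20 mL/min/kg to 80 mL/min/kg on this reading.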

Compound 4, clearance: 6.2 mL/min/kg
Estimate against measurement, compound 4: 7.3-fold (0.86 log units) above; measured number outside the range, below it.
By their numbers in this assay, from the lowest: compounds 4 and 1 (each within the scatter of the next); then compounds 2 and 3 (each within the scatter of the next).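

In this assay the substituent on the aromatic ring is not a silent place in this series. Methoxy in place of hydrogen left the number within the scatter, whereas trifluoromethyl in place of methyl on the oxygen gives a 10-fold lower number from compound 3 to compound 4 (1.00 log units; beyond the scatter) and takes the compound out of the high pair. Compared with the hydrogen of compound 2, trifluoromethoxy gives a 9.1-fold lower number from compound 2 to compound 4 (0.96 log units; beyond the scatter), so an oxygen substituent at this place does not by itself go with the lower number, and the difference lies in methyl against trifluoromethyl on that oxygen. Nothing measured here accounts for the size of this step.

The compounds shown leave open whether the low number is particular to trifluoromethoxy or is shared by other groups at this place, such as difluoromethoxy or a nitrile on the aromatic ring. Within the data shown here, with only one trifluoromethoxy compound in hand, it also remains open whether the same step would appear on a different core, such as that of compound 1.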